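A Fluorophenyl Analogue Tested on Breast Cancer Cells

A few compounds are considered here, and "the series" means these few. Any claim that something is new, unique, unknown or untested is made for them only; others in the source may bear on it.

Three sulfonamides sharing one core were examined in a functional assay on MCF7 cells (Homo sapiens) for antiproliferative activity, read by sulforhodamine B assay, with a stated time of 48 h; on this read-out lower numbers stand for stronger inhibition and higher numbers for weaker inhibition. Compound 1 `O=C1NCCN1c1ccc(S(=O)(=O)Nc2ccc(Br)cc2)cc1` gives 240 nM, compound 2 `Cc1ccc(NS(=O)(=O)c2ccc(N3CCNC3=O)cc2)c(C)c1` gives 230 nM, and compound 3 `CCc1cccc(NS(=O)(=O)c2ccc(N3CCNC3=O)cc2)c1` gives 130 nM. The gap a 1.8-fold lower number from compound 2 to compound 3 (0.25 log units; within the scatter) and the gap a 1.8-fold lower number from compound 1 to compound 3 (0.27 log units; within the scatter) both lie within the scatter, as does a 1.0-fold lower number from compound 1 to compound 2 (0.02 log units; within the scatter), so on the numbers shown the three compounds cannot be told apart.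

Compound 4 `O=C1NCCN1c1ccc(S(=O)(=O)Nc2ccc(F)cc2)cc1` differs from compound 3 in one place: 4-fluorophenyl in place of 3-ethylphenyl on a sulfonamide nitrogen. The step from compound 1 to compound 3 is the closest comparison, since it exchanges a 4-bromophenyl for the 3-ethylphenyl and amounts to a 1.8-fold lower number from compound 1 to compound 3 (0.27 log units; within the scatter), a shift within the scatter. Returning to a 4-halophenyl is therefore expected to move the number in this assay by at most a similar amount, if at all, and compound 4 is estimated at 220 nM, between 90 nM and 550 nM, with an expected step of a 1.7-fold higher number from compound 3 to compound 4 (0.23 log units; within the scatter).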

Compound 4, half-maximal inhibitory concentration: 690 nM
Estimate against measurement, compound 4: 3.1-fold (0.50 log units) below, outside the stated range (above it).
By their numbers in this assay, from the lowest: compounds 3, 2 and 1 (each within the scatter of the next); then compound 4.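

In this assay, going by these compounds alone, the choice of aryl group on a sulfonamide nitrogen now makes a readable difference: a 5.3-fold higher number from compound 3 to compound 4 (0.72 log units; beyond the scatter) and a 3.0-fold higher number from compound 2 to compound 4 (0.48 log units; beyond the scatter) are both beyond the scatter, which no step among the first three compounds was. A single halogen exchange is enough, since fluoro in place of bromo on an aromatic carbon gives a 2.9-fold higher number from compound 1 to compound 4 (0.46 log units; beyond the scatter) and so the 4-fluorophenyl cannot stand in for the 4-bromophenyl on this core. No measurement available here accounts for these steps.

The compounds shown leave open whether a chloro or a plain hydrogen in place of the fluoro would read like compound 1 or like compound 4. They also leave open how a phenyl carrying an amine or a carboxylic acid would behave at this nitrogen in this assay and whether the same halogen exchange would hold with the other aryl groups.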